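This account rests on a few compounds, and the source may have more. Where it says the series, first, only, none or still open, it means among the compounds named here.

Measured so far in this series:
compound 1 `O=C1Nc2ccc(Br)cc2/C1=N/NC(=S)N/N=C/c1c(Cl)cccc1Cl` — 6730 nM
compound 2 `Cc1ccc2c(c1)/C(=N/NC(=S)N/N=C/c1c(Cl)cccc1Cl)C(=O)N2` — 3870 nM

Both numbers come from a functional assay on COS-7 cells (Chlorocebus aethiops) for inhibition, read by MTT assay; on this read-out lower numbers stand for stronger inhibition and higher numbers for weaker inhibition. Compound 1 stands at the higher of the two numbers; compound 2 gives the lower one. Within the data shown here, the only step between measured compounds is the exchange of bromo for methyl on an aromatic carbon of the shared core, which gave a 1.7-fold lower number from compound 1 to compound 2 (0.24 log units; within the scatter) and so changes nothing that can be read as a real difference.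

Compound 3 `O=C1Nc2ccc(Br)cc2/C1=N/NC(=S)N/N=C/c1ccc(Br)cc1` is the next one to be measured in this assay. It differs from compound 1 in 4-bromophenyl in place of 2,6-dichlorophenyl on a carbon with a double bond to nitrogen. Among the measured compounds shown here, this change lies on the other aromatic ring, not on the shared core, and no measured pair differs there. The step from compound 1 to compound 2 therefore does not bear on it directly; it only shows that the one variation tried so far stayed within the scatter. With nothing to indicate a shift in either direction, the working expectation for compound 3 is no step beyond the scatter, with a wide range to allow for the untested position. Compound 3 is estimated at 6000 nM, in the range 2000 nM to 20000 nM. This estimate amounts to an expected step of a 1.1-fold lower number from compound 1 to compound 3 (0.05 log units; within the scatter).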

Compound 3, half-maximal inhibitory concentration: 5180 nM
The estimate for compound 3 lay 1.2-fold (0.06 log units) above the measured number; the measured number falls inside the stated range.
By their numbers in this assay, from the lowest: compounds 2, 3 and 1 (each within the scatter of the next).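

In this assay, among these compounds, the exchange of 2,6-dichlorophenyl for 4-bromophenyl on a carbon with a double bond to nitrogen gives a 1.3-fold lower number from compound 1 to compound 3 (0.11 log units; within the scatter) and so provides the first reading at this position, which the earlier pair did not touch. The entering group has one bromine where the leaving group has two chlorine atoms, yet this change of halogen and of halogen count on the ring leaves compound 1 and compound 3 within the scatter of each other, so the read-out does not separate these two groups. Among the compounds shown here, nothing measured so far offers an explanation for this result.

On these data alone, both groups at this position are halogen-bearing phenyl rings, so it remains open whether a phenyl ring carrying an amine or a carboxylic acid, or a longer alkyl chain in place of the ring, would also stay within the scatter. As far as these compounds go, it is equally open whether methyl in place of bromo on the shared core would give a similar reading when 4-bromophenyl is the group at this position.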